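Sulfamoyl for methylpiperazinyl: one swap, two cores

A few compounds are considered here, and "the series" means these few. Any claim that something is new, unique, unknown or untested is made for them only; others in the source may bear on it.

Compound 1 `CN1CCN(c2ccc(Nc3ncc(/N=C/c4ccc(C(F)(F)F)cc4)c(NC4CCCC4)n3)cc2)CC1` and compound 2 `NS(=O)(=O)c1ccc(Nc2ncc(/N=C/c3ccc(C(F)(F)F)cc3)c(NC3CCCC3)n2)cc1` share a core and differ by sulfamoyl in place of 4-methylpiperazin-1-yl on an aromatic carbon. In a functional assay on HCT-116 cells (Homo sapiens) for antiproliferative activity, read by MTT assay (a higher number here means a weaker inhibitor, a lower number a stronger inhibitor), compound 1 gives > 100000 nM, which is a limit of the assay and not a number. Compound 2 gives > 100000 nM, likewise a limit. The step that the two limits leave unreadable from compound 1 to compound 2 stays unreadable because the limit of > 100000 nM in this assay, at which 2 of the 3 values shown sit, covers both ends of it.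

Compound 3 `CCOC(=O)/C=N/c1cnc(Nc2ccc(N3CCN(C)CC3)cc2)nc1NC(C)C` sits on a different core; the difference between the two cores is not broken down here. In this assay, among the measured compounds shown here, compound 3 gives 13600 nM, the only number among the three values. Compound 4 `CCOC(=O)/C=N/c1cnc(Nc2ccc(S(N)(=O)=O)cc2)nc1NC(C)C` applies the same change to compound 3, namely (sulfamoyl in place of 4-methylpiperazin-1-yl on an aromatic carbon).

Since the measured pair yields no readable size, the expectation rests on compound 3 with its value 13600 nM as the anchor. Compound 4 is expected near 20000 nM, between 5000 nM and 100000 nM. The expected step of a 1.5-fold higher number from compound 3 to compound 4 (0.17 log units; within the scatter) is estimated as small and uncertain, with a real chance that only a limit is reported.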

Compound 4, half-maximal inhibitory concentration: 49100 nM
For compound 4 the middle estimate is 2.5-fold (0.39 log units) below the measured one, and the stated range covers the measured number.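

In this assay the swap of 4-methylpiperazin-1-yl for sulfamoyl on the core of compound 3 gives a 3.6-fold higher number from compound 3 to compound 4 (0.56 log units; beyond the scatter) and so marks a modest loss of antiproliferative activity on this core. On the core of compound 1 the same swap cannot be read, because compound 1 and compound 2 both stand at a limit and not at a number: the limit of > 100000 nM in this assay, at which 2 of the 4 values shown sit. One readable step on one core therefore shows neither that the change carries over between the cores nor that it fails to.

Open, going by these compounds, is how a carboxylic acid on the same aromatic carbon would read on either core. Also open, on these data alone, is whether any compound on the core of compound 1 gives a number instead of a limit.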